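Methyl for trifluoromethyl across two related fused cores

The source may hold more compounds than are shown below. What is called first, only, known or untested is meant among the compounds shown, and "the series" means these compounds.

Compound 1 `Nc1nc2ccc(C(F)(F)F)cn2c1-c1ccc(O)cc1` and compound 2 `Nc1nc2cc(C(F)(F)F)ccn2c1-c1ccc(O)cc1` hold the same atoms joined differently; the difference between the two cores is not broken down here. In an assay on isolated protein for inhibition of ubiquitin carboxyl-terminal hydrolase 1 (Homo sapiens) (a higher number here means a weaker inhibitor, a lower number a stronger inhibitor), compound 1 gives > 100000 nM, a limit of the assay. Compound 2 likewise returns only a limit, > 100000 nM. Compound 3 `Cc1ccc2nc(N)c(-c3ccc(O)cc3)n2c1` arises from compound 1 by methyl in place of trifluoromethyl on an aromatic carbon. In this assay compound 3 also sits at a limit, > 100000 nM. Hence a step that the two limits leave unreadable from compound 1 to compound 3; the limit of > 100000 nM in this assay, at which 3 of the 3 values shown sit, leaves the step unreadable. Compound 4 `Cc1ccn2c(-c3ccc(O)cc3)c(N)nc2c1` carries the same kind of change from compound 2, (methyl in place of trifluoromethyl on an aromatic carbon), the place differing in lying opposite the ring nitrogen rather than two atoms from it. Compound 4 is expected to give 150000 nM in this assay, most likely again only a limit, the expected step that the limit leaves unreadable from compound 2 to compound 4 standing beside the unreadable a step that the two limits leave unreadable from compound 1 to compound 3. This rests on compound 2, which shows only the limit > 100000 nM. The expected lower end for compound 4 is 40000 nM. The expected upper end for compound 4 is 600000 nM.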

Compound 4, half-maximal inhibitory concentration: > 100000 nM
Compound 4: a limit, no number (the forecaster's own chance of this, stated with the estimate: 85%); the middle value lies beyond the limit too.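

Compound 4 gives no readable step from compound 2, so the methyl-for-trifluoromethyl change stays unreadable on both cores: the limit of > 100000 nM in this assay, at which 4 of the 4 values shown sit. The compounds shown leave open whether either group affects inhibition on either core.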